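From pentyl to 3-hydroxypropyl on the shared core

A few compounds are considered here, and "the series" means these few. Any claim that something is new, unique, unknown or untested is made for them only; others in the source may bear on it.

compound 1 `CCCCCn1nc(C(=O)N[C@H]2COc3ccccc3N(C)C2=S)nc1Cc1ccccc1` gives 805 nM
compound 2 `CC(C)CCn1nc(C(=O)N[C@H]2COc3ccccc3N(C)C2=S)nc1Cc1ccccc1` gives 3640 nM
compound 3 `COCCn1nc(C(=O)N[C@H]2COc3ccccc3N(C)C2=S)nc1Cc1ccccc1` gives 566 nM

All three values come from a functional assay on HT-29 cells (Homo sapiens) for inhibition, read by luminescence and CellTiter-Glo, with a stated time of 24 h (a lower number here means that less compound is needed, a higher number that more compound is needed for the effect), and cover a narrow set of chains on one shared core. Compound 1 has a close neighbour and a more distant one: the nearest step is a 1.4-fold lower number from compound 1 to compound 3 (0.15 log units; within the scatter) and the furthest is a 4.5-fold higher number from compound 1 to compound 2 (0.66 log units; beyond the scatter) on the same scale.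

Compound 4 `CN1C(=S)[C@@H](NC(=O)c2nc(Cc3ccccc3)n(CCCO)n2)COc2ccccc21` has not yet been measured. Its difference from compound 1 is hydroxy in place of ethyl on a saturated chain carbon, three bonds along the chain from an aromatic nitrogen, in words hydroxy in place of ethyl on a saturated chain carbon, three bonds along the chain from an aromatic nitrogen. The same difference also reads pentyl to 3-hydroxypropyl.

Going by the values given here, no measured compound carries a hydroxy group, so the evidence is indirect. Among the compounds with values here, the nearest precedent is methoxy in place of propyl, which gave a 1.4-fold lower number from compound 1 to compound 3 (0.15 log units; within the scatter) as its result. The isopropyl chain stands apart, with a 4.5-fold higher number from compound 1 to compound 2 (0.66 log units; beyond the scatter) and a 6.4-fold lower number from compound 2 to compound 3 (0.81 log units; beyond the scatter) as its two steps, and this shows that changes at the chain end can matter in this assay as well.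

The expected step is a 1.1-fold higher number from compound 1 to compound 4 (0.05 log units; within the scatter) and so none beyond the scatter is expected, though with wide uncertainty. Compound 4 is estimated at 900 nM with an expected range from 300 nM to 3000 nM as its bounds.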

Compound 4, half-maximal effective concentration: 209 nM
Compound 4: the middle estimate sits 4.3-fold (0.63 log units) above what was measured; measured number below the stated range.
By their numbers in this assay, from the lowest: compound 4; then compounds 3 and 1 (each within the scatter of the next); then compound 2.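

In this assay, the 3-hydroxypropyl chain separates itself from the pentyl chain, with a 3.9-fold lower number from compound 1 to compound 4 (0.59 log units; beyond the scatter), and also from the methoxy-bearing chain, with a 2.7-fold lower number from compound 3 to compound 4 (0.43 log units; beyond the scatter). The earlier compounds had shown only that the pentyl and methoxy-bearing chains could not be told apart at this position, and that the isopropyl-ended chain of compound 2 gave the highest number; compound 4 now shows that a change at this place can also lower the number beyond the scatter, and it has the lowest number of the four. The widest span at this position is now a 17-fold lower number from compound 2 to compound 4 (1.24 log units; beyond the scatter), but the compounds shown offer no measured property that could account for any of these steps.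

With a single hydroxy compound, the compounds shown leave open whether the lower number follows the hydroxy group itself or depends on its place along the chain, a question that a 2-hydroxyethyl or 4-hydroxybutyl chain would address. They also leave open how an amine or a carboxylic acid at the end of the same chain would compare.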